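The source may report more compounds than this note shows. Statements on the series, on what has been measured and on what is new or still open speak of the compounds shown alone.

Measured compounds in a physicochemical assay for lipophilicity; a lower number here means a more polar compound, a higher number a more lipophilic compound:

Compound 1 `O=C(Nc1ccc(Cl)cc1)Nc1ccc2c(c1)C(Nc1ccc(Cl)cc1Cl)=NS2(=O)=O` gives 4.24.
Compound 2 `CCOC(=O)C(=CNc1ccc2c(c1)C(Nc1ccc(Cl)cc1)=NS2(=O)=O)C(=O)OCC` gives 2.39.
Compound 3 `O=C(Nc1ccccc1)Nc1ccc(OC2=NS(=O)(=O)c3ccccc32)cc1` gives 2.89.

Compound 2 stands lowest of the three numbers in this assay. Its nearest neighbour is compound 3, whose value lies higher by an amount beyond the scatter; the furthest is compound 1, whose value lies well beyond the scatter above it. No pair among these three differs in one place only, so no single-point step in this assay is available from the measured set.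

The step to compound 4 `CCOC(=O)C(=CNc1ccc2c(c1)C(Nc1cccc(Br)c1)=NS2(=O)=O)C(=O)OCC` is a single change on compound 2: 3-bromophenyl in place of 4-chlorophenyl on an amine nitrogen. One halogen-bearing phenyl ring is exchanged for another halogen-bearing phenyl ring of the same atom count, with no change in hydrogen-bond donors, acceptors or charge, and the rest of the structure, including the diester enamine chain, is kept.

With no measured step of this kind in the series, the expectation in this assay is a small upward shift, of a size that may not clear the scatter. Compound 4 is estimated at 2.55, range 2.2 to 2.9. This expected step from compound 2 to compound 4 is a number 0.16 log units higher from compound 2 to compound 4 (within the scatter).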

Compound 4, partition coefficient: 2.48
Beside the measured number, compound 4's estimate is 0.07 log units above it; measured number inside the range.
By their numbers in this assay, from the lowest: compounds 2 and 4 (each within the scatter of the next); then compound 3; then compound 1.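

In this assay, among these compounds, the series now has its first step that changes one place only (a number 0.09 log units higher from compound 2 to compound 4 (within the scatter)), something compounds 1, 2 and 3 could not show, as no pair among them differs in one place. On the amine nitrogen whose other neighbour is the carbon with a double bond to nitrogen, and with the diester enamine chain kept, 3-bromophenyl and 4-chlorophenyl are not told apart by this assay, at least for this single pair. No measurement on hand bears on the reason for the size of this step.

The step exchanges the halogen and its place on the phenyl ring together, so the share of each in the result cannot be separated, and 3-chlorophenyl or 4-bromophenyl on the same nitrogen would be needed to divide them. Also open, on these data alone, is whether this tolerance holds for a group of a different kind at this nitrogen, such as a phenyl ring carrying a carboxylic acid or an amine, and whether it holds on a compound that has the urea of compound 1 in place of the diester enamine chain.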